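Swapping a Benzothiazole for a Dimethylpyrimidine in Liver-Cell Growth

The compounds below may be only part of what the source reports. "The series", "measured", "known", "first", "only" and "open" are said of these compounds alone.

Four related compounds are considered here. Compound 1 `O=C(N/N=C/c1c[nH]c2ccccc12)c1ccc(CSc2nc3ccccc3s2)cc1` and compound 2 `COc1cc(/C=N/NC(=O)c2ccc(CSc3nc4ccccc4s3)cc2)cc(OC)c1OC` carry the same sulfur-linked group but are built on different cores; the difference between the two cores is not broken down here. Compound 3 `COc1cc(/C=N/NC(=O)c2ccc(CSc3nc(C)cc(C)n3)cc2)cc(OC)c1OC` and compound 4 `Cc1cc(C)nc(SCc2ccc(C(=O)N/N=C/c3c[nH]c4ccccc34)cc2)n1` differ from them by the same change: 4,6-dimethylpyrimidin-2-yl in place of 1,3-benzothiazol-2-yl on a sulfur in compound 3 relative to compound 2, and 4,6-dimethylpyrimidin-2-yl in place of 1,3-benzothiazol-2-yl on a sulfur in compound 4 relative to compound 1. The place of the change reads the same in both pairs, so it is the same change made on two cores.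

In a functional assay on HepG2 cells (Homo sapiens) for inhibition, read by MTT assay, with a stated time of 72 h (on this read-out higher numbers stand for weaker inhibition and lower numbers for stronger inhibition), compound 1 reaches only a limit of the measurement, > 80 ug/mL. Compound 2 likewise gives only a limit in this assay, > 80 ug/mL. Compound 3 gives 33.3 ug/mL in this assay. The measured step is an at least 2.4-fold lower number from compound 2 to compound 3 (0.38 log units; beyond the scatter); its exact size cannot be fixed because of the limit of > 80 ug/mL in this assay, at which 2 of the 3 values shown sit.

Compound 4 has not yet been measured in this assay. It repeats the change just described. A similar drop is expected. Compound 4 is expected to show a step of an at least 2.0-fold lower number from compound 1 to compound 4 (0.30 log units; that floor lies within the scatter), resting on the measured step of an at least 2.4-fold lower number from compound 2 to compound 3 (0.38 log units; beyond the scatter). Since compound 1 itself sits at a limit, the starting point is uncertain and the expectation is correspondingly wide. Compound 4 is estimated at 40 ug/mL, with a likely range from 15 ug/mL to 80 ug/mL.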

Compound 4, half-maximal inhibitory concentration: 34.1 ug/mL
Beside the measured number, compound 4's estimate is 1.2-fold (0.07 log units) above it; measured number inside the range.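

Measured in this assay, compound 4 bears out the expected direction: 4,6-dimethylpyrimidin-2-yl in place of 1,3-benzothiazol-2-yl on the sulfur gives an at least 2.3-fold lower number from compound 1 to compound 4 (0.37 log units; beyond the scatter). The change therefore lowers the number on both cores shown, which is the most these four compounds can say about carrying it from one core to the other, and the two steps look alike only as far as the data allow: the same change on two cores in this assay, an at least 2.4-fold lower number (0.38 log units; beyond the scatter) from compound 2 to compound 3 and an at least 2.3-fold lower number (0.37 log units; beyond the scatter) from compound 1 to compound 4; the limit leaves it open whether they differ Neither step has a known true size, and the apparent likeness of the two may say little, since each starts from a benzothiazole compound that gives only a limit and not a number: the limit of > 80 ug/mL in this assay, at which 2 of the 4 values shown sit.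

The compounds shown leave open what a plain pyrimidin-2-yl group or a pyridin-2-yl group would give on the same sulfur, and so whether the lower numbers go with the pyrimidine ring or with its two methyl groups. Going by these compounds, it also remains open whether the same change would lower the number on a third core, as two cores are too few to establish a general rule.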